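A few compounds are considered here, and "the series" means these few. Any claim that something is new, unique, unknown or untested is made for them only; others in the source may bear on it.

The measured compounds, with their numbers in an ADME assay on Vero cells (Chlorocebus sabaeus) for cytotoxicity, read by MTT assay; a higher number here means a weaker inhibitor, a lower number a stronger inhibitor:

Compound 1, `CN(Cc1ccc(F)cc1)c1cc(C(=O)Nc2ccccc2)ncn1`, gives 297000 nM.
Compound 2, `CN(Cc1ccc(C(F)(F)F)nc1)c1cc(C(=O)Nc2ccccc2)ncn1`, gives 258000 nM.
Compound 3, `CN1CCN(c2ccc(NC(=O)c3cc(N(C)Cc4ccc(C(F)(F)F)nc4)ncn3)cc2)CC1`, gives 45200 nM.

Compound 1 and compound 2 differ in more than one place, so the difference between the two cores is not broken down here; their two numbers lie within the scatter of each other. Compound 3 comes from compound 2 by one change, (4-methylpiperazin-1-yl in place of hydrogen on an aromatic carbon). That change made a 5.7-fold lower number from compound 2 to compound 3 (0.76 log units; beyond the scatter), a step that the scatter does not explain away.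

Compound 4, `CN1CCN(c2cccc(NC(=O)c3cc(N(C)Cc4ccc(F)cc4)ncn3)c2)CC1`, is not yet measured in this assay. It comes from compound 1 by 4-methylpiperazin-1-yl in place of hydrogen on an aromatic carbon. Compared with the change from compound 2 to compound 3, the entering group and the leaving hydrogen are the same, but the place is not worded the same: in compound 3 it sits para to a large group, in compound 4 meta to a large group. It is therefore the same kind of change, not the same change, and it has been seen only once among the measured compounds.

Beside the measured step from compound 2 to compound 3, an expected 5.0-fold lower number from compound 1 to compound 4 (0.69 log units; beyond the scatter) seems reasonable for compound 1 to compound 4, resting on the one measured step and on compound 1 giving 297000 nM. For compound 4 the estimated value is 60000 nM, expected to fall between 25000 nM and 150000 nM.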

Compound 4, half-maximal inhibitory concentration in the Vero assay: 118000 nM
Estimate against measurement, compound 4: 2.0-fold (0.29 log units) below, within the range that was stated.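

In the Vero assay, putting 4-methylpiperazin-1-yl on the aromatic ring of the core of compound 1 gave a 2.5-fold lower number from compound 1 to compound 4 (0.40 log units; beyond the scatter), a drop in the same direction as on the other core, and the two steps agree in size as far as repeated measurement can tell: the same change on two cores in the Vero assay, a 5.7-fold lower number (0.76 log units; beyond the scatter) from compound 2 to compound 3 and a 2.5-fold lower number (0.40 log units; beyond the scatter) from compound 1 to compound 4, 2.3-fold (0.36 log units) apart, within the scatter of two such steps. Within the data shown here, this supports carrying the change between these two cores as a lowering of the number, but it rests on only two pairs, which differ both in the core and in where the group sits on the ring, so it gives no rule for other cores and cannot separate those two differences. In a physicochemical assay for solubility, using the shake flask method, measured as kinetic solubility, with a stated time of 2 h, at pH 7.4 (on this read-out higher numbers stand for higher solubility and lower numbers for lower solubility), the same change came with an at least 14-fold higher number from compound 1 to compound 4 (1.17 log units; beyond the scatter), a step read on one core only. In the physicochemical assay compound 1 gives < 5000 nM, which is a limit of the assay and not a number: the limit of < 5000 nM in the physicochemical assay, at which 1 of the 2 values shown sits. In the physicochemical assay compound 4 gives 74000 nM.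

The compounds shown leave open whether a different group in the same place, such as a morpholine ring or a simple dimethylamino group, would move the numbers in the same way. They also leave open how much the place on the ring matters by itself, a question that would take 4-methylpiperazin-1-yl at both places on a single core.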